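Compound 4 in the macrophage toxicity series

A few compounds are considered here, and "the series" means these few. Any claim that something is new, unique, unknown or untested is made for them only; others in the source may bear on it.

Measured so far in a toxicity assay on cells (Macrophage, Mus musculus, strain BALB/c) for cytotoxicity, read by MTT assay; a lower number here means a stronger inhibitor, a higher number a weaker inhibitor
- compound 1 `C=CCOc1cc(OC)c(C(=O)/C=C/c2cccc(OC)c2)c(OCC=C)c1` gives 13100 nM
- compound 2 `COc1cc(O)cc(O)c1C(=O)/C=C/Cc1ccccc1` gives 27000 nM
- compound 3 `COc1cc(/C=C/C(=O)c2c(O)cc(O)cc2OC)ccc1O` has no number ("not determined" (no result reported))

In this assay compound 1 has the lower of the two numbers, and compound 2 lies just beyond the scatter above it. Compound 4 `C=CCOc1cc(OC)c(C(=O)/C=C/c2ccc(Cl)cc2)c(OCC=C)c1` differs from compound 1 by 4-chlorophenyl in place of 3-methoxyphenyl on a double-bonded chain carbon bound to a double-bonded chain carbon and nothing else. Going by the values given here, no measured pair shows this change, so the series gives no direct size for it. In this assay no step beyond the scatter is expected, with no firm direction. The expected step is a 1.3-fold lower number from compound 1 to compound 4 (0.12 log units; within the scatter) by this estimate. Compound 4 is estimated at 10000 nM (expected range 3500 nM to 30000 nM).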

Compound 4, half-maximal inhibitory concentration: 13000 nM
Compound 4: middle estimate off by 1.3-fold (0.11 log units), on the low side, and the stated range covers the measured number.
By their numbers in this assay, from the lowest: compounds 4 and 1 (each within the scatter of the next); then compound 2.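

In this assay, going by these compounds alone, the exchange of 3-methoxyphenyl for 4-chlorophenyl on a double-bonded chain carbon bound to a double-bonded chain carbon gives a 1.0-fold lower number from compound 1 to compound 4 (0.00 log units; within the scatter) and is the first direct size for a change at this place. On this single pair, the place does not separate the two substituted phenyl groups. Nothing measured here bears on why the two compounds read alike.

Still open, on these data alone, is whether 3-chlorophenyl or 4-methoxyphenyl would read the same. Also open, as far as these compounds go, is whether a phenyl carrying an amine or a carboxylic acid would hold the number at this place.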